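3-Chlorobenzyl to 3-fluorobenzyl: compound 3 to compound 4

The compounds below may be only part of what the source reports. "The series", "measured", "known", "first", "only" and "open" are said of these compounds alone.

In a functional assay on GBM2 cells (Homo sapiens) for antiproliferative activity, read by WST assay, with a stated time of 72 h (a lower number here means a stronger inhibitor, a higher number a weaker inhibitor), compound 3 (`O=C(Nc1ccccc1F)Nc1cc2ncncc2cc1OCc1cccc(Cl)c1`) gives 4400 nM as its value, within the scatter of compound 1 (`O=C(Nc1ccccc1F)Nc1cc2ncncc2cc1OCc1ccccc1`) at 4500 nM in the same read-out. Compound 2 (`O=C(Nc1ccc(Cl)c(Cl)c1)Nc1cc2ncncc2cc1OCc1cccc(F)c1`) gives 1500 nM as a lower number than compound 3, beyond the scatter.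

Compound 4 (`O=C(Nc1ccccc1F)Nc1cc2ncncc2cc1OCc1cccc(F)c1`) carries 3-fluorobenzyl where compound 3 carries 3-chlorobenzyl (fluoro in place of chloro on an aromatic carbon), that is, fluoro in place of chloro on an aromatic carbon. Within the data shown here, the one measured single-place step that bears on this is a 1.0-fold lower number from compound 1 to compound 3 (0.01 log units; within the scatter) with chloro in place of hydrogen on an aromatic carbon, and it lies within the scatter. Compound 2 also holds the (3-fluorobenzyl)oxy group but differs from compound 4 elsewhere too, so it does not isolate the swap. No step beyond the scatter is therefore expected in this assay for this change. The estimated step is a 1.1-fold lower number from compound 3 to compound 4 (0.04 log units; within the scatter) and stays within the scatter. For compound 4 the estimated value is 4000 nM with an expected range from 2200 nM to 7500 nM in this measurement.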

Compound 4, half-maximal inhibitory concentration: 6400 nM
Compound 4: the middle estimate sits 1.6-fold (0.20 log units) below what was measured; measured number inside the range.
By their numbers in this assay, from the lowest: compound 2; then compounds 3, 1 and 4 (each within the scatter of the next).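

In this assay, 3-fluorobenzyl in place of 3-chlorobenzyl gives a 1.5-fold higher number from compound 3 to compound 4 (0.16 log units; within the scatter), and fluoro in place of hydrogen gives a 1.4-fold higher number from compound 1 to compound 4 (0.15 log units; within the scatter). Together with a 1.0-fold lower number from compound 1 to compound 3 (0.01 log units; within the scatter), these steps lie within the scatter, so hydrogen, chloro and fluoro at this place on the ring are not told apart. With 3-fluorobenzyl held constant, 2-fluorophenyl in place of 3,4-dichlorophenyl on the amide-type nitrogen gives a 4.3-fold higher number from compound 2 to compound 4 (0.63 log units; beyond the scatter), which lies beyond the scatter, and no supporting data bear on these results.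

From the compounds shown here alone, whether an amine or a carboxylic acid at this place on the ring would separate from hydrogen, chloro and fluoro remains open. Going by these compounds, it is also open whether the step between 2-fluorophenyl and 3,4-dichlorophenyl has a similar size with 3-chlorobenzyl or unsubstituted benzyl on the shared core.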